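Swapping methoxy for chloro on compound 3

The source may hold more compounds than are shown below. What is called first, only, known or untested is meant among the compounds shown, and "the series" means these compounds.

compound 1 `Cc1ccc(-c2nn(-c3ccccc3)cc2-c2nc3ccccc3[nH]2)cc1`: 4010 nM
compound 2 `Cc1ccc(-c2nn(-c3ccccc3)cc2-c2nc3ccccc3n2S(=O)(=O)c2ccc(Cl)cc2)cc1`: 3550 nM
compound 3 `COc1ccc(S(=O)(=O)n2c(-c3cn(-c4ccccc4)nc3-c3ccc(F)cc3)nc3ccccc32)cc1`: 350 nM

In a functional assay on A549 cells (Homo sapiens) for antiproliferative activity, read by MTT assay, with a stated time of 24 h (a lower number here means a stronger inhibitor, a higher number a weaker inhibitor), compound 3 gives 350 nM as the lowest number of the three, and the values of compound 1 and compound 2 both lie beyond the scatter above it. Compound 4 `O=S(=O)(c1ccc(Cl)cc1)n1c(-c2cn(-c3ccccc3)nc2-c2ccc(F)cc2)nc2ccccc21` has not been measured yet. Its difference from compound 3 is chloro in place of methoxy on an aromatic carbon and amounts to chloro in place of methoxy on an aromatic carbon, para to a large group, turning 4-methoxyphenyl into 4-chlorophenyl.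

Among the compounds with values here, no measured step makes this swap. The closest evidence is indirect: a 1.1-fold lower number from compound 1 to compound 2 (0.05 log units; within the scatter) when (4-chlorophenyl)sulfonyl replaces hydrogen on an aromatic nitrogen. Compound 2 (3550 nM) carries the same (4-chlorophenyl)sulfonyl group as compound 4 and has a much higher number than compound 3. However, compound 2 also differs from compound 3 in a second place, and the data cannot separate the two changes. A modest move towards a higher number therefore seems likely, with more room upward than downward. The expected step is a 1.7-fold higher number from compound 3 to compound 4 (0.23 log units; within the scatter) and remains uncertain. In this assay the estimated value for compound 4 is 600 nM with an expected range from 180 nM to 2500 nM as its limits.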

Compound 4, half-maximal inhibitory concentration: 3170 nM
Compound 4: middle estimate off by 5.3-fold (0.72 log units), on the low side; measured number above the stated range.
By their numbers in this assay, from the lowest: compound 3; then compounds 4, 2 and 1 (each within the scatter of the next).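

Going from (4-methoxyphenyl)sulfonyl to (4-chlorophenyl)sulfonyl in this assay gives a 9.1-fold higher number from compound 3 to compound 4 (0.96 log units; beyond the scatter), so this one position, para to a large group, has a large bearing on the read-out, and chloro there does not stand in for methoxy. The other step, fluoro in place of methyl on an aromatic carbon, gives a 1.1-fold lower number from compound 2 to compound 4 (0.05 log units; within the scatter), which shows that with chloro on the sulfonyl-bound ring, this second change makes no difference that can be told from the scatter, and it places the low number of compound 3 with its methoxy rather than with its fluoro. Nothing measured here explains why methoxy and chloro differ so much at this position.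

Methoxy is the only group at this position that goes with a low number, so it remains open whether ethoxy, hydroxyl or an amine in the same place would match it or fall back towards chloro. Methoxy also appears only alongside fluoro, which leaves open whether its advantage would carry over to the methyl-bearing series.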